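Replacing 3-methoxyphenyl with 4-acetylphenyl: an expected small step

The compounds below may be only part of what the source reports. "The series", "measured", "known", "first", "only" and "open" are said of these compounds alone.

Compound 1 `O=C(CCc1cccc2c1B(O)OC2)Nc1ccc(I)cc1`: 33000 nM
Compound 2 `CC(=O)c1ccc(-c2cccc(NC(=O)CCc3ccc4c(c3)B(O)OC4)c2)cc1`: 59000 nM
Compound 3 `COc1cccc(-c2cccc(NC(=O)CCc3cccc4c3COB4O)c2)c1`: 76000 nM

All three numbers come from a functional assay on MDA-MB-231 cells (Homo sapiens) for antiproliferative activity, read by MTT assay, with a stated time of 72 h; a lower number here means a stronger inhibitor, a higher number a weaker inhibitor. Compound 3, at 76000 nM, sits within the scatter of compound 2 and beyond the scatter of compound 1, whose number is lower. Compound 3 and compound 2 therefore share the upper end of this small set.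

The next compound to be considered is compound 4 `CC(=O)c1ccc(-c2cccc(NC(=O)CCc3cccc4c3COB4O)c2)cc1`. It differs from compound 3 by having 4-acetylphenyl in place of 3-methoxyphenyl on an aromatic carbon, meta to a large group (4-acetylphenyl in place of 3-methoxyphenyl on an aromatic carbon). Among the measured compounds shown here, no pair of measured compounds differs in only one place, so the data give no direct measure of such a change.

The entering 4-acetylphenyl is also present on compound 2, which gives 59000 nM, and that value lies within the scatter of compound 3. No change beyond the scatter is therefore expected in this assay. The estimate means an expected step of a 1.2-fold lower number from compound 3 to compound 4 (0.07 log units; within the scatter), with no clear direction. For compound 4 the expected value is 65000 nM, with an estimated range from 30000 nM to 120000 nM.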

Compound 4, half-maximal inhibitory concentration: 41000 nM
Beside the measured number, compound 4's estimate is 1.6-fold (0.20 log units) above it, within the range that was stated.
By their numbers in this assay, from the lowest: compounds 1, 4, 2 and 3 (each within the scatter of the next, the first and the last beyond it).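

In this assay, among the compounds shown here, the exchange of 3-methoxyphenyl for 4-acetylphenyl on an aromatic carbon, meta to a large group, gives a 1.9-fold lower number from compound 3 to compound 4 (0.27 log units; within the scatter) and so provides the first direct reading of this change at this position: the two groups are not separated by this measurement. Compound 4 also forms a one-place pair with compound 2, in which two groups with the same printed atom and ring counts replace each other on a saturated chain carbon, two bonds along the chain from a carbonyl carbon, and this exchange gives a 1.4-fold lower number from compound 2 to compound 4 (0.16 log units; within the scatter), so it too yields no separation in this assay. The evidence available offers no explanation for either step. 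

The compounds shown leave open whether an amine or a carboxylic acid in place of the acetyl group, or a longer chain in place of the saturated chain, would give a number beyond the scatter of compound 4. They also leave open whether the two forms of the group exchanged from compound 2 to compound 4 would remain within the scatter of each other when paired with 3-methoxyphenyl instead of 4-acetylphenyl.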